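The source may hold more compounds than are shown below. What is called first, only, known or untested is meant among the compounds shown, and "the series" means these compounds.

Two compounds of the series carry numbers in a functional assay on B16-F10 cells (Mus musculus) for cytotoxicity, read by CCK-8 assay, with a stated time of 48 h; on this read-out higher numbers stand for weaker inhibition and lower numbers for stronger inhibition. Compound 1 `O=c1oc2ccccc2c(Cl)c1/C=N/c1ccc(S(=O)(=O)Nc2nccs2)cc1` gives 300 nM. Compound 2 `Cc1ccc2oc(=O)c(/C=N/c3ccc(S(=O)(=O)Nc4nccs4)cc3)c(Cl)c2c1`, which carries a methyl in place of hydrogen on an aromatic carbon, gives 280 nM in this assay; the step of a 1.1-fold lower number from compound 1 to compound 2 (0.03 log units; within the scatter) lies within the scatter. On these two numbers compound 2 holds the lower one, but its gap to compound 1 is within the scatter, so no order between them can be claimed.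

Compound 3 `Cc1ccc2oc(=O)c(/C=N/c3ccc(S(=O)(=O)Nc4nccc(C)n4)cc3)c(Cl)c2c1` differs from compound 2 by 4-methylpyrimidin-2-yl in place of 1,3-thiazol-2-yl on a sulfonamide nitrogen. Within the data shown here, no measured step touches the group on the sulfonamide nitrogen; the only measured step, a 1.1-fold lower number from compound 1 to compound 2 (0.03 log units; within the scatter), alters an aromatic substituent elsewhere and stayed within the scatter, so it bears only loosely on this change. The step expected in this assay is therefore one of no clear direction, a 1.1-fold higher number from compound 2 to compound 3 (0.03 log units; within the scatter). For compound 3 the estimated value in this assay is 300 nM, with a range from 120 nM to 800 nM.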

Compound 3, half-maximal inhibitory concentration: 270 nM
The estimate for compound 3 lay 1.1-fold (0.05 log units) above the measured number, within the range that was stated.
By their numbers in this assay, from the lowest: compounds 3, 2 and 1 (each within the scatter of the next).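

Among these compounds, the group on the sulfonamide nitrogen changes here for the first time, and in this assay the replacement of 1,3-thiazol-2-yl by 4-methylpyrimidin-2-yl gives a 1.0-fold lower number from compound 2 to compound 3 (0.02 log units; within the scatter). At this position, a five-membered aromatic ring with 2 hetero atoms and a methyl-bearing six-membered aromatic ring with 2 hetero atoms therefore cannot be told apart on this read-out, even though the sulfur is lost and the heavy-atom count differs. Nothing on hand bears on why the two groups read alike.

On these data alone, both groups on this nitrogen are aromatic rings, so it remains open whether an acetyl group, a short alkyl chain or a plain hydrogen there would keep the number in the same range. The share of the methyl also stays open, since the unsubstituted pyrimidin-2-yl group is not among the compounds shown.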